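The source may hold more compounds than are shown below. What is called first, only, known or untested is meant among the compounds shown, and "the series" means these compounds.

Compound 1 `O=c1nc(N2CCC(c3ccc(CO)cc3)CC2)sc2c([N+](=O)[O-])cc(C(F)(F)F)cc12`: 19600 nM
Compound 2 `O=c1nc(N2CCC(Oc3ccc(OC(F)(F)F)cc3)CC2)sc2c([N+](=O)[O-])cc(C(F)(F)F)cc12`: > 93000 nM (a limit)
Compound 3 `CC(=O)c1ccc(N2CCN(c3nc(=O)c4cc(C(F)(F)F)cc([N+](=O)[O-])c4s3)CC2)cc1`: > 105000 nM (a limit)

In a toxicity assay on HeLa cells (Homo sapiens) for cytotoxicity, read by colorimetric assay, with a stated time of 72 h (on this read-out higher numbers stand for lower toxicity in this test and lower numbers for higher toxicity in this test), compound 3 gives > 105000 nM, which is a limit and not a number. Compound 4 `O=C(CN1CCN(c2nc(=O)c3cc(C(F)(F)F)cc([N+](=O)[O-])c3s2)CC1)Nc1ccccn1` carries ((pyridin-2-yl)carbamoyl)methyl in place of 4-acetylphenyl on an amine nitrogen in a ring. Within the data shown here, no measured step makes this exchange. The only one, an at least 4.7-fold higher number from compound 1 to compound 2 (0.67 log units; beyond the scatter), swaps different groups on a saturated ring carbon, so it bears on this change only loosely. It does show that a group exchange away from the shared core can move this assay beyond the scatter. A step of no greater size is expected here, with a lower number if any. The expected change is an at least 1.5-fold lower number from compound 3 to compound 4 (0.17 log units; that floor lies within the scatter). Compound 4 is estimated at 70000 nM, with an expected range from 20000 nM to 150000 nM.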

Compound 4, half-maximal cytotoxic concentration: 44500 nM
Beside the measured number, compound 4's estimate is 1.6-fold (0.20 log units) above it, and the stated range covers the measured number.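

In this assay, moving from 4-acetylphenyl to ((pyridin-2-yl)carbamoyl)methyl on the amine nitrogen in a ring gives an at least 2.3-fold lower number from compound 3 to compound 4 (0.37 log units; beyond the scatter). This shows that a change at this nitrogen can also move the number beyond the scatter, here towards higher toxicity in this test. The true size of the step stays open because compound 3 stands at a limit and not at a number: the limit of > 105000 nM in this assay, at which 1 of the 4 values shown sits.

The aromatic ring and the linking atoms change together, so the step cannot be assigned to either. From the compounds shown here alone, whether a carboxylic acid or a longer chain on this nitrogen would give a similar number also remains open.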